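Isopropyl on the Aromatic Ring of Compound 1

The source may report more compounds than this note shows. Statements on the series, on what has been measured and on what is new or still open speak of the compounds shown alone.

Within the data shown here, compound 1 `CC(C)(C)OC(=O)/C=C1/C(=O)Nc2ccccc21` gives 87.6% in a functional assay on MDA-MB-231 cells (Homo sapiens) for inhibition, read by CCK-8 assay, with a stated time of 72 h, tested at 20 uM (on this read-out higher numbers stand for more inhibition of growth at the one concentration tested and lower numbers for less inhibition of growth), one of only two numbers measured so far, and the other lies within the scatter of it: compound 2 `CN1C(=O)/C(=C/C(=O)OC(C)(C)C)c2ccccc21` gives 86.6% in this assay. Among the measured compounds shown here, the one measured step, a number 1 percentage points lower from compound 1 to compound 2 (within the scatter), alters the amide-type nitrogen rather than the aromatic ring. Compound 3 `CC(C)c1ccc2c(c1)/C(=C\C(=O)OC(C)(C)C)C(=O)N2` differs from compound 1 by isopropyl in place of hydrogen on an aromatic carbon. For the measured compounds named here, no measured step touches the aromatic ring, so a step of similar size, a number 1.6 percentage points lower from compound 1 to compound 3 (within the scatter), is expected. Compound 3 is therefore estimated at 86%, within 70% to 96%.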

Compound 3, percent growth inhibition at one concentration: 87.7%
Beside the measured number, compound 3's estimate is 1.7 percentage points below it; low and high end bracket the measured number.
By their numbers in this assay, from the lowest: compounds 2, 1 and 3 (each within the scatter of the next).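

Among these compounds, until now no measured step touched the aromatic ring. In this assay, isopropyl in place of hydrogen on an aromatic carbon gives a number 0.1 percentage points higher from compound 1 to compound 3 (within the scatter), so at this position a group of this size leaves the number within the scatter of compound 1. No evidence is available to explain this result. Still open, as far as these compounds go, is whether other groups at this position, such as an amine or a carboxylic acid, would also stay within the scatter. Also open, from the compounds shown here alone, is whether isopropyl would do the same on the other aromatic carbons of the ring.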